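Naphthalen-2-ylmethyl in Place of Butyl on an Aromatic Nitrogen

The source may report more compounds than this note shows. Statements on the series, on what has been measured and on what is new or still open speak of the compounds shown alone.

Of the compounds shown here, three built on one shared core have been measured in an assay on HEK-293T cells for inhibition of Bile acid receptor (Homo sapiens), read by a beta-lactamase reporter, with a stated time of 16 h; on this read-out higher numbers stand for weaker inhibition and lower numbers for stronger inhibition. Compound 1 `Cc1ccc(-c2nn(-c3ccc(F)cc3)cc2C(=O)Nc2ccc(C)c(S(=O)(=O)N3CCOCC3)c2)cc1` gives 2490 nM, compound 2 `Cc1ccc(-c2nn(-c3ccc(Cl)cc3Cl)cc2C(=O)Nc2ccc(C)c(S(=O)(=O)N3CCOCC3)c2)cc1` gives 1240 nM, and compound 3 `CCCCn1cc(C(=O)Nc2ccc(C)c(S(=O)(=O)N3CCOCC3)c2)c(-c2ccc(C)cc2)n1` gives 11500 nM, the highest of the three numbers. Between the two aryl-bearing compounds the difference is small, as the step of a 2.0-fold lower number from compound 1 to compound 2 (0.30 log units; within the scatter) shows. Exchanging the aryl group on the aromatic nitrogen for butyl raised the number in both cases: a 4.6-fold higher number from compound 1 to compound 3 (0.66 log units; beyond the scatter) and a 9.3-fold higher number from compound 2 to compound 3 (0.97 log units; beyond the scatter).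

Compound 4 `Cc1ccc(-c2nn(Cc3ccc4ccccc4c3)cc2C(=O)Nc2ccc(C)c(S(=O)(=O)N3CCOCC3)c2)cc1` differs from compound 3 by naphthalen-2-yl in place of propyl on a saturated chain carbon bound to an aromatic nitrogen. Two aromatic rings thus return to the substituent on the aromatic nitrogen, now one bond further out than in compound 1 or compound 2. The two steps leading to compound 3 both ran beyond the scatter toward higher numbers, so a move back in the other direction is the expectation here. Compound 4 is therefore expected to show a lower number, with the estimated step of a 3.8-fold lower number from compound 3 to compound 4 (0.58 log units; beyond the scatter) bringing it close to the aryl-bearing compounds. Compound 4 is estimated at 3000 nM, with a range from 1000 nM to 9000 nM.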

Compound 4, half-maximal inhibitory concentration: 844 nM
Beside the measured number, compound 4's estimate is 3.6-fold (0.55 log units) above it; measured number below the stated range.
By their numbers in this assay, from the lowest: compounds 4, 2 and 1 (each within the scatter of the next, the first and the last beyond it); then compound 3.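

In this assay, for the compounds shown here, the aromatic nitrogen keeps its low numbers when a saturated carbon stands before the aromatic rings: butyl to (naphthalen-2-yl)methyl gives a 14-fold lower number from compound 3 to compound 4 (1.13 log units; beyond the scatter), the largest step seen at this position so far. Set against the aryl groups bound directly to that nitrogen, the result divides, with a 1.5-fold lower number from compound 2 to compound 4 (0.17 log units; within the scatter) showing no real separation from the 2,4-dichlorophenyl group and a 3.0-fold lower number from compound 1 to compound 4 (0.47 log units; beyond the scatter) showing a clear one from the 4-fluorophenyl group. A directly attached aryl group is therefore not required here, and butyl alone stands apart.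

No supporting data explain why the numbers move this way. As far as these compounds go, whether the gain follows the two fused rings or the connecting carbon stays open, and a benzyl or a naphthalen-1-ylmethyl group on the same nitrogen would bear on that.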